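This account rests on a few compounds, and the source may have more. Where it says the series, first, only, none or still open, it means among the compounds named here.

Compound 1 `O=C(NC1CCCCC1)Oc1cccc(-c2cccc(Oc3ccccc3)c2)c1` gives 420 nM in an assay on cell membranes for binding affinity to Fatty-acid amide hydrolase 1 (Rattus norvegicus); on this read-out lower numbers stand for stronger inhibition and higher numbers for weaker inhibition.
Compound 2 `O=C(NC1CCCCC1)Oc1cccc(-c2cccc([N+](=O)[O-])c2)c1` gives 49.6 nM in this assay.
Compound 3 `NS(=O)(=O)c1cccc(-c2cccc(OC(=O)NC3CCCCC3)c2)c1` gives 26.5 nM in this assay.

Compound 3 carries the lowest of the three numbers. Its distance from compound 1 is clear: a 16-fold lower number from compound 1 to compound 3 (1.20 log units; beyond the scatter). Its distance from compound 2 is not: a 1.9-fold lower number from compound 2 to compound 3 (0.27 log units; within the scatter), so compound 2 and compound 3 cannot be placed in order on these data.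

Compound 4 `O=C(NC1CCCCC1)Oc1cccc(-c2cccc(CO)c2)c1` has not yet been measured. The change from compound 3 to compound 4 is hydroxymethyl in place of sulfamoyl on an aromatic carbon. Within the data shown here, no measured step involves a hydroxymethyl group, so none speaks directly to this change. The steps at the same position are an 8.5-fold lower number from compound 1 to compound 2 (0.93 log units; beyond the scatter) and a 16-fold lower number from compound 1 to compound 3 (1.20 log units; beyond the scatter): they show that the group there can shift the number considerably, with phenoxy giving the highest number and nitro and sulfamoyl each giving a lower number. With no guide to hydroxymethyl itself, a modest rise in the number from compound 3 to compound 4 is expected, a 2.6-fold higher number from compound 3 to compound 4 (0.42 log units; beyond the scatter), with a wide range. Compound 4 is therefore estimated to give 70 nM in this assay, from 20 nM to 250 nM.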

Compound 4, half-maximal inhibitory concentration: 8.67 nM
The estimate for compound 4 lay 8.1-fold (0.91 log units) above the measured number; measured number below the stated range.
By their numbers in this assay, from the lowest: compound 4; then compounds 3 and 2 (each within the scatter of the next); then compound 1.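

Hydroxymethyl takes the number lower than any earlier group at this position, with a 3.1-fold lower number from compound 3 to compound 4 (0.49 log units; beyond the scatter) and a 5.7-fold lower number from compound 2 to compound 4 (0.76 log units; beyond the scatter) and, against the phenoxy group, a 48-fold lower number from compound 1 to compound 4 (1.69 log units; beyond the scatter) in this assay. Among these compounds, the earlier compounds left nitro and sulfamoyl unseparated, and this is the first group there to stand clearly apart from both, so the lowest number at this position does not depend on either of them; hydroxymethyl has fewer heavy atoms and one hydrogen-bond acceptor fewer than sulfamoyl. Nothing given here accounts for this drop.

Going by these compounds, whether a methoxymethyl group, which keeps the oxygen but loses the hydrogen-bond donor, would hold the number this low remains open. So does the effect of an aminomethyl group, a carboxylic acid or a longer hydroxyethyl chain in the same place.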